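This account rests on a few compounds, and the source may have more. Where it says the series, first, only, none or still open, it means among the compounds named here.

Measured so far in a physicochemical assay for solubility, using the shake flask method, measured as kinetic solubility, at pH 7.4; on this read-out higher numbers stand for higher solubility and lower numbers for lower solubility:
- compound 1 `Fc1ccccc1Nc1nc(-c2ccccn2)cs1`: compound 1 gives 45400 nM
- compound 2 `COc1ccccc1Nc1nc(-c2ccccn2)cs1`: compound 2 gives 1200 nM
- compound 3 `COc1cccc(-c2csc(Nc3ccccc3F)n2)c1`: compound 3 gives 49300 nM

Compound 2 and compound 1 differ in one place, (fluoro in place of methoxy on an aromatic carbon). The step is a 38-fold higher number from compound 2 to compound 1 (1.58 log units; beyond the scatter). Compound 3 carries a different core from compound 2; the difference between the two cores is not broken down here. In this assay compound 3 stands within the scatter of compound 1 and well apart from compound 2.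

Compound 4 `Fc1cccc(-c2csc(Nc3ccccc3F)n2)c1` is not yet measured. It differs from compound 3 by fluoro in place of methoxy on an aromatic carbon. This is the same kind of change as that from compound 2 to compound 1, but the place is not the same: there the fluoro sits ortho to a large group, here meta to a large group.

For compound 4 the expected step in this assay is a 1.2-fold higher number from compound 3 to compound 4 (0.09 log units; within the scatter), smaller than a 38-fold higher number from compound 2 to compound 1 (1.58 log units; beyond the scatter); that rests on compound 3 already standing at 49300 nM, a number within the scatter of compound 1 at 45400 nM. The estimate for compound 4 is 60000 nM, expected between 20000 nM and 150000 nM.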

Compound 4, solubility: < 1000 nM
Compound 4: only a limit was reported (the forecaster's own chance of this, stated with the estimate: 5%); at least 60-fold (1.77 log units) between middle value and limit.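

In this assay, fluoro in place of methoxy on an aromatic carbon gives a 38-fold higher number from compound 2 to compound 1 (1.58 log units; beyond the scatter) on one core, but an at least 49-fold lower number from compound 3 to compound 4 (1.69 log units; beyond the scatter) on the other, where the fluoro sits meta to a large group. The change therefore does not carry over in direction between these two cores, yet with one pair per core and a different place in each, the data do not separate the effect of core from that of place, and they do not show why the two steps part. The reading of compound 4 is only a limit of the assay, so the full size of its step remains unknown: the limit of < 1000 nM in this assay, at which 1 of the 4 values shown sits.

Open, from the compounds shown here alone, is how an amine, a carboxylic acid or a longer chain in place of the methoxy would read in this assay on either core. Also open, going by these compounds, is whether the fluoro would give the same low reading at another place on that six-membered aromatic ring of carbon only.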